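Residence time notes: amidine in place of amidoxime

The source may report more compounds than this note shows. Statements on the series, on what has been measured and on what is new or still open speak of the compounds shown alone.

Measured so far:
compound 1, `CCC(CC)O[C@@H]1C=C(C(=O)O)C[C@H](NC(C)=N)[C@H]1NC(C)=O` — 2.1 h
compound 2, `CCOC(=O)C1=C[C@@H](OC(CC)CC)[C@H](NC(C)=O)[C@@H](N/C(N)=N\O)C1` — 2.8 h

In an ADME assay on the whole organism (strain Sprague-Dawley) with Rattus norvegicus as the target, read by LC-MS, at a dose of 50 mg/kg by the oral route (a lower number here means that the compound disappears faster, a higher number that the compound lasts longer), compound 2 gives 2.8 h. Compound 1, the acid carrying the same ether chain, gives 2.1 h in this assay; the two numbers lie within the usual scatter of each other, so no ordering between them is claimed.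

Compound 3, `CCOC(=O)C1=C[C@@H](OC(CC)CC)[C@H](NC(C)=O)[C@@H](NC(C)=N)C1`, is the ethyl ester of compound 2 with a changed group on the amine nitrogen:

a group of 3 heavy atoms (2 carbon, 1 nitrogen; no ring) in place of a group of 4 heavy atoms (1 carbon, 2 nitrogen, 1 oxygen; no ring), on an amine nitrogen

For the measured compounds named here, no measured pair shows this change on its own. Compound 1 carries the entering group of 3 heavy atoms and gives 2.1 h, which offers no reason to expect a step beyond the scatter. The expected step of a 1.2-fold lower number from compound 2 to compound 3 (0.07 log units; within the scatter) is therefore small. Compound 3 is estimated at 2.4 h in this assay, with a range from 1.2 h to 4.8 h.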

Compound 3, mean residence time in the Rattus norvegicus assay: 1.62 h
For compound 3 the middle estimate is 1.5-fold (0.17 log units) above the measured one; the range from low to high includes it.
By their numbers in the Rattus norvegicus assay, from the lowest: compounds 3, 1 and 2 (each within the scatter of the next).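

In the Rattus norvegicus assay, the change on the amine nitrogen gives a 1.7-fold lower number from compound 2 to compound 3 (0.24 log units; within the scatter), and ethyl in place of hydrogen on an oxygen next to a carbonyl group gives a 1.3-fold lower number from compound 1 to compound 3 (0.11 log units; within the scatter), so neither change yet separates these compounds by mean residence time. In a physicochemical assay for solubility, read by HPLC, in phosphate buffer, with a stated time of 20 min, at pH 2.0 (a higher number here means a more soluble compound, a lower number a less soluble compound), compound 2 gives > 50000000 nM, which is a limit of the assay and not a number. In the physicochemical assay compound 3 gives > 50000000 nM, which is likewise a limit.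

The step between these two compounds in the physicochemical assay cannot be read: the limit of > 50000000 nM in the physicochemical assay, at which 2 of the 2 values shown sit. On these data alone, how a plain amine or a longer chain on this amine nitrogen would stand in the Rattus norvegicus assay remains open, as does whether any group at this place gives a step beyond the scatter.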